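Bromo for Fluoro on the Phenyl: Expected Antiproliferative Outcome

A few compounds are considered here, and "the series" means these few. Any claim that something is new, unique, unknown or untested is made for them only; others in the source may bear on it.

Compound 1, `O=C(Nc1ccc(Oc2ccnc3[nH]ccc23)c(F)c1)c1cc2cccnc2n(-c2ccc(Br)cc2)c1=O`: 1510 nM
Compound 2, `Cn1ccc2c(Oc3ccc(NC(=O)c4cc5cccnc5n(-c5ccc(Br)cc5)c4=O)cc3)ccnc21`: "not determined" (no result reported)
Compound 3, `Cn1ccc2c(Oc3ccc(NC(=O)c4cc5cccnc5n(-c5ccc(F)cc5)c4=O)cc3F)ccnc21`: 1320 nM

In a functional assay on U-87MG ATCC cells for antiproliferative activity against U-87 MG (Homo sapiens), read by MTT assay, with a stated time of 72 h (a lower number here means a stronger inhibitor, a higher number a weaker inhibitor), compound 1 gives 1510 nM and compound 3 gives 1320 nM. Compound 3 thus shows the lower of the two numbers, but its gap to compound 1 lies within the scatter, so the two cannot be told apart on these data. For compound 2 the entry reads "not determined" (no result reported), so nothing can be said of it in this assay.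

Compound 4, `Cn1ccc2c(Oc3ccc(NC(=O)c4cc5cccnc5n(-c5ccc(Br)cc5)c4=O)cc3F)ccnc21`, differs from compound 3 by bromo in place of fluoro on an aromatic carbon. For the measured compounds named here, no measured pair isolates this change. Compound 1 also carries the bromo group, yet it differs from compound 4 elsewhere as well, so it cannot stand in for the step; still, compound 1 and compound 3 sit within the scatter of one another. The step from compound 3 to compound 4 is therefore expected to be small, a 1.1-fold higher number from compound 3 to compound 4 (0.03 log units; within the scatter), with no direction beyond the scatter. Compound 4 is estimated at 1400 nM, within a range from 600 nM to 3500 nM.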

Compound 4, half-maximal inhibitory concentration: 2580 nM
For compound 4 the middle estimate is 1.8-fold (0.27 log units) below the measured one; measured number inside the range.
By their numbers in this assay, from the lowest: compounds 3, 1 and 4 (each within the scatter of the next).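

For the compounds shown here, this pair is the first to isolate 4-fluorophenyl to 4-bromophenyl: in this assay the change gives a 2.0-fold higher number from compound 3 to compound 4 (0.29 log units; within the scatter) and so does not separate the two halogens at this position. With bromo held in place, methyl in place of hydrogen on the aromatic nitrogen gives a 1.7-fold higher number from compound 1 to compound 4 (0.23 log units; within the scatter) and likewise separates neither compound from the other, so neither single change has a readable effect here. Nothing available bears on the origin of these numbers.

Going by these compounds, whether a group of another kind on this aromatic carbon, such as an amine, a carboxylic acid or a longer alkyl chain, would give a step beyond the scatter remains open. On these data alone, compound 2 has no number, so the steps to it cannot be read, and the part played by the ring fluoro that it lacks stays unknown.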